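The source may report more compounds than this note shows. Statements on the series, on what has been measured and on what is new or still open speak of the compounds shown alone.

Compound 1 `CS(=O)(=O)Oc1c(C(=O)NCc2ccc(F)cc2)nc(Br)c2cccnc12` carries a (methylsulfonyl)oxy group on the shared core. In a functional assay on HCT-116 cells (Homo sapiens) for cytotoxicity, read by MTT assay, with a stated time of 72 h (a higher number here means a weaker inhibitor, a lower number a stronger inhibitor), compound 1 gives > 20000 nM. That figure is a limit of the assay, not a number. Compound 1 thus sits at the limit of > 20000 nM in this assay, at which 1 of the 3 values shown sits. Compound 2 `N[C@H]1CC[C@H](Nc2c(C(=O)NCc3ccc(Oc4ccccc4)cc3)nc(Br)c3cccnc23)CC1` has "not determined" (no result reported) in this assay. Compound 3 `COc1ccc(CNC(=O)c2nc(Br)c3cccnc3c2N[C@H]2CC[C@H](N)CC2)cc1`, which instead carries an amine on the core, gives 3000 nM in this assay. Compound 4 `C[C@H](Nc1c(C(=O)NCc2ccc(F)cc2)nc(Br)c2cccnc12)c1ccccc1` differs from compound 1 in one way: (1-phenylethyl)amino in place of (methylsulfonyl)oxy on an aromatic carbon. Within the data shown here, no measured pair shows this exact change, but since compound 3 with its amine reaches 3000 nM, the step of an at least 4.0-fold lower number from compound 1 to compound 4 (0.60 log units; beyond the scatter) is expected to be a gain in potency beyond the usual scatter. Compound 4 is therefore estimated at 5000 nM, within a range from 1000 nM to 20000 nM.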

Compound 4, half-maximal inhibitory concentration: > 20000 nM
Compound 4 ended at the assay's limit (the forecaster's own chance of this, stated with the estimate: 25%); middle value at least 4.0-fold (0.60 log units) away from the limit.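

Among these compounds, compound 1 and compound 4 both stop at a limit of the assay rather than a number, so no step between them can be read: the limit of > 20000 nM in this assay, at which 2 of the 4 values shown sit. Still open, as far as these compounds go, is whether (1-phenylethyl)amino in place of (methylsulfonyl)oxy changes potency at all.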